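The source may report more compounds than this note shows. Statements on the series, on what has been measured and on what is new or still open speak of the compounds shown alone.

Measured compounds:
- Compound 1, `CC(C)(C)c1ccc(CCC(=O)Nc2ccc3c(c2)OCCO3)cc1`: 150 nM
- Compound 2, `CC(C)(C)c1ccc(/C(=C/C(=O)Nc2ccc3c(c2)OCCO3)c2ccncc2)cc1`: 44 nM

Both compounds were tested in a functional assay on CHO cells for inhibition of transient receptor potential cation channel subfamily V member 1 (Homo sapiens); a higher number here means a weaker inhibitor, a lower number a stronger inhibitor. Compound 1 gives 150 nM, and compound 2 gives 44 nM. Of these two numbers, compound 2 has the lower one, and the gap to compound 1 lies beyond the usual scatter of repeated measurements, so compound 2 is the stronger inhibitor of the pair.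

Compound 3, `CC(C)(C)c1ccc(/C(=C/C(=O)Nc2ccc3c(c2)OCCO3)CCC(=O)O)cc1`, has not yet been measured in this assay. It differs from compound 2 in one place: 2-carboxyethyl in place of pyridin-4-yl on a double-bonded chain carbon bound to an aromatic carbon and a double-bonded chain carbon. Within the data shown here, no step between two measured compounds matches this change, so there is no direct precedent to lean on. The expectation is a step toward a weaker inhibitor, a 9.1-fold higher number from compound 2 to compound 3 (0.96 log units; beyond the scatter), clearly beyond the scatter. On that basis compound 3 is estimated at 400 nM, with a likely range from 100 nM to 2000 nM.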

Compound 3, half-maximal inhibitory concentration: > 4000 nM
Compound 3: no number, only a limit; the forecaster's own chance of this, stated with the estimate: 10%; at least 10-fold (1.00 log units) between middle value and limit.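

Putting 2-carboxyethyl in place of pyridin-4-yl on a double-bonded chain carbon bound to an aromatic carbon and a double-bonded chain carbon gives, in this assay, an at least 90-fold higher number from compound 2 to compound 3 (1.95 log units; beyond the scatter), a large step. Compound 3 stands at a limit of the assay and not at a number, so the step is a minimum and its full size is unknown: the limit of > 4000 nM in this assay, at which 1 of the 3 values shown sits.

Compound 2 alone could not show how much the group at this position matters, and this pair shows that the choice of group there can change the result greatly.

The ring leaves and the acid chain enters in one change, so the two contributions cannot be told apart. A methyl ester of the same chain, a plain propyl chain, an amine on that chain or a phenyl ring at this position would help to separate them.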